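Swapping Fluoro for Hydrogen on Two Sulfonamide Cores

A few compounds are considered here, and "the series" means these few. Any claim that something is new, unique, unknown or untested is made for them only; others in the source may bear on it.

Compound 1 `CC1CCN(C2CCN(S(=O)(=O)c3ccc(-c4ccccc4F)cc3)CC2)CC1` and compound 2 `CC1CCN(C2CCN(S(=O)(=O)c3ccc(-c4ccccc4)cc3)CC2)CC1` share one core, while compound 3 `Cc1cc(C)c(S(=O)(=O)N2CCC(N3CCC(Cc4ccccc4F)CC3)CC2)c(C)c1` and compound 4 `Cc1cc(C)c(S(=O)(=O)N2CCC(N3CCC(Cc4ccccc4)CC3)CC2)c(C)c1` share another; the difference between the two cores is not broken down here. In an ADME assay on HCT-116 cells (Homo sapiens) for cytotoxicity, read by CellTiter-Glo, with a stated time of 72 h (on this read-out lower numbers stand for stronger inhibition and higher numbers for weaker inhibition), compound 1 gives > 5000 nM, which is a limit of the assay rather than a number. In this assay compound 2 gives > 5000 nM, again a limit. The change between them, (hydrogen in place of fluoro on an aromatic carbon), therefore produces a step that the two limits leave unreadable from compound 1 to compound 2. In this assay compound 3 gives > 5000 nM, once more a limit. Within the data shown here, every measured value so far sits at the limit of > 5000 nM in this assay, at which 3 of the 3 values shown sit. Compound 4 carries the same change relative to compound 3, (hydrogen in place of fluoro on an aromatic carbon), with the leaving and entering groups placed exactly as before.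

Among the measured compounds shown here, because a step that the two limits leave unreadable from compound 1 to compound 2 could not be read and every value so far sits at the limit of > 5000 nM in this assay, at which 3 of the 3 values shown sit, the step from compound 3 to compound 4 is expected to be a step that the limit leaves unreadable from compound 3 to compound 4. Compound 4 is therefore expected to give 8000 nM in this assay, most likely reported as a limit, with an estimated range from 4000 nM to 20000 nM.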

Compound 4, half-maximal inhibitory concentration: > 5000 nM
Compound 4: a limit, no number (the forecaster's own chance of this, stated with the estimate: 85%); the middle value lies beyond the limit too.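

In this assay compound 4 gives > 5000 nM, again a limit and not a number. Neither the change from compound 1 to compound 2 nor the change from compound 3 to compound 4 can be read as a step, and all the values stand at one limit: the limit of > 5000 nM in this assay, at which 4 of the 4 values shown sit.

The compounds shown leave open whether hydrogen in place of fluoro alters this read-out at all on either core, and what actual number any of the four compounds would give.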